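Dimethylamino in Place of Amino: Compound 1 to Compound 3

The source may report more compounds than this note shows. Statements on the series, on what has been measured and on what is new or still open speak of the compounds shown alone.

Among the measured compounds shown here, in a functional assay on A2780 cells (Homo sapiens) for antiproliferative activity, read by MTT assay, with a stated time of 48 h (on this read-out higher numbers stand for weaker inhibition and lower numbers for stronger inhibition), compound 1 (`C=C(c1ccc(OC)cc1NC(=O)CN)c1ccc(OC)c2c1C=CC(C)(C)O2`) gives 400 nM, the higher of the two numbers available so far. Compound 2 (`C=C(c1cc(OC)c(OC)c(OC)c1)c1ccc(OC)cc1NC(=O)CNC`) gives 140 nM, a lower number by a margin beyond the scatter. These two compounds differ in more than one place, so their gap cannot be assigned to any single group.

The next compound to be read is compound 3 (`C=C(c1ccc(OC)cc1NC(=O)CN(C)C)c1ccc(OC)c2c1C=CC(C)(C)O2`), which keeps the rest of compound 1 unchanged. It carries dimethylamino in place of amino on a saturated chain carbon bound to a carbonyl carbon.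

For the measured compounds named here, no measured pair isolates this change, so the expectation is weakly founded. Going by the values given here, the only hint is that compound 2, at 140 nM, sits under compound 1 with a substituted amine on its chain, though other parts of the molecule differ as well. The expected move is small and slightly downward, not beyond the scatter: a 1.3-fold lower number from compound 1 to compound 3 (0.12 log units; within the scatter). For compound 3 the estimated value is 300 nM, with an expected range of 100 nM to 900 nM.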

Compound 3, half-maximal inhibitory concentration: 670 nM
The estimate for compound 3 lay 2.2-fold (0.35 log units) below the measured number; low and high end bracket the measured number.
By their numbers in this assay, from the lowest: compound 2; then compounds 1 and 3 (each within the scatter of the next).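

In this assay, dimethylamino in place of amino on a saturated chain carbon bound to a carbonyl carbon gives a 1.7-fold higher number from compound 1 to compound 3 (0.22 log units; within the scatter), the only step among the compounds shown that isolates a single change, and compound 1 and compound 3 cannot be told apart on this read-out. The change takes the group from 1 hydrogen-bond donor to 0 and from 1 heavy atom to 3, so for this pair neither difference in these counts registers beyond the scatter, and a free amino hydrogen is not required at this position for a value in this range. No measurement of another kind accompanies this step, so the result stands without any explanation.

Compound 2, at 140 nM, carries a methyl-substituted amine on the same chain but differs from compound 1 in more than one place, so the compounds shown do not tell whether that amine contributes to its value on the core of compound 1. From the compounds shown here alone, how far this tolerance extends also stays open, since a piperidine ring, a carboxylic acid or a longer chain at this position would test the change beyond the two amines compared here.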